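Swapping an amine substituent for a urea: expected half-life

The source may report more compounds than this note shows. Statements on the series, on what has been measured and on what is new or still open speak of the compounds shown alone.

Of the compounds shown here, three built on one shared core have been measured in an ADME assay (liver) for metabolic stability, with Liver microsome (Homo sapiens) as the target, read by LC-MS, using microsomes and NADPH, tested at 1 uM; on this read-out higher numbers stand for a longer-lived compound and lower numbers for a shorter-lived compound. Compound 1 `CC(C)(C)c1cc(NC(=O)[C@@H]2CCCCN2CC2CC2)no1` gives 0.15 h, the lowest of the three numbers. Compound 2 `CC(C)(C)c1cc(NC(=O)[C@@H]2CCCCN2C(=O)C2CCCCC2)no1` gives 0.483 h, and compound 3 `CC(C)(C)c1cc(NC(=O)[C@@H]2CCCCN2C(=O)CC2CCOCC2)no1` gives 1.83 h. The step from compound 1 to compound 2 is a 3.2-fold higher number from compound 1 to compound 2 (0.51 log units; beyond the scatter), the step from compound 1 to compound 3 is a 12-fold higher number from compound 1 to compound 3 (1.09 log units; beyond the scatter), and the step from compound 2 to compound 3 is a 3.8-fold higher number from compound 2 to compound 3 (0.58 log units; beyond the scatter).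

Compound 4 `CC(C)(C)c1cc(NC(=O)[C@@H]2CCCCN2C(=O)N2CCOCC2)no1` differs from compound 1 in one place: (morpholin-4-yl)carbonyl in place of cyclopropylmethyl on an amine nitrogen in a ring. Both measured steps starting from compound 1 bear on this change, since each of them also replaces the cyclopropylmethyl on the same ring nitrogen with a group that carries a carbonyl. One of those steps was modest and the other large, and both lie beyond the scatter in the direction of a longer-lived compound. Compound 3, whose entering group also contains a six-membered ring with oxygen, shows the larger of the two. A step of similar size, toward a higher number, is therefore expected for compound 4; the expected step is a 10-fold higher number from compound 1 to compound 4 (1.00 log units; beyond the scatter). For compound 4 the estimated half-life in this assay is 1.5 h, expected to fall between 0.5 h and 4.5 h.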

Compound 4, half-life: > 2 h
Compound 4: a limit, no number (the forecaster's own chance of this, stated with the estimate: 5%); middle value at least 1.3-fold (0.12 log units) away from the limit.
By their numbers in this assay, from the lowest: compound 1; then compound 2; then compound 3. At a limit, above all of these: compound 4.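

In this assay compound 4 stands at a limit and not at a number: the limit of > 2 h in this assay, at which 1 of the 4 values shown sits.

Even so, the step is readable in its lower bound: an at least 13-fold higher number from compound 1 to compound 4 (1.12 log units; beyond the scatter) shows that a carbonyl group carrying morpholin-4-yl, with a ring nitrogen rather than a carbon attached to the carbonyl carbon, can replace cyclopropylmethyl at this position, and an at least 4.1-fold higher number from compound 2 to compound 4 (0.61 log units; beyond the scatter) shows that the group on that carbonyl carbon still matters when morpholin-4-yl replaces cyclohexyl. Against compound 3 the result is less decisive, since an at least 1.0-fold higher number from compound 3 to compound 4 (0.03 log units; that floor lies within the scatter) gives a floor within the usual scatter, so no order can be set between morpholin-4-yl and (oxan-4-yl)methyl on the carbonyl carbon.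

The compounds shown leave open how far past the limit the half-life of compound 4 lies. They also leave open whether the oxygen of the morpholin-4-yl ring counts for anything here, a question that a piperidin-1-yl group on the same carbonyl carbon, with a carbon in place of that oxygen, would address directly.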